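This account rests on a few compounds, and the source may have more. Where it says the series, first, only, none or still open, it means among the compounds named here.

Two compounds share one core and differ in a single group. Compound 1 `CCOc1ccc(Nc2nc3nonc3nc2Nc2ccccc2F)cc1` carries an ethyl on an oxygen on an aromatic ring, and in an assay on mitochondria from L6 cells (Rattus norvegicus) for activation, with a stated time of 90 min (on this read-out higher numbers stand for an effect only at larger amounts of compound and lower numbers for an effect already at smaller amounts), compound 1 gives 3800 nM. Compound 2 `Fc1ccccc1Nc1nc2nonc2nc1Nc1ccc(OC(F)(F)F)cc1` carries a trifluoromethyl on that oxygen instead, and in this assay compound 2 gives 1300 nM. Going by the values given here, the single step measured so far, a 2.9-fold lower number from compound 1 to compound 2 (0.47 log units; beyond the scatter), lies beyond the scatter but is modest. Among the compounds with values here, compound 2 thus holds the lowest of the two numbers, with compound 1 as its only and nearest neighbour.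

Compound 3 `Fc1ccccc1Nc1nc2nonc2nc1Nc1ccc(C(F)(F)F)cc1` has not yet been measured. Its change from compound 2 is as follows: trifluoromethyl in place of trifluoromethoxy on an aromatic carbon. Within the data shown here, no measured step bears on this exchange: the one known step concerns what sits on the oxygen, not the removal of the oxygen itself, so it offers no direct guide. The expectation for compound 3 in this assay is therefore no step beyond the scatter, no change at the digits printed from compound 2 to compound 3 (within the scatter). Compound 3 is estimated at 1300 nM in this assay, within a range from 450 nM to 3800 nM.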

Compound 3, half-maximal effective concentration: 270 nM
Compound 3: middle estimate off by 4.8-fold (0.68 log units), on the high side; the measured number lies below the stated range.
By their numbers in this assay, from the lowest: compound 3; then compound 2; then compound 1.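

In this assay, the exchange of trifluoromethoxy for trifluoromethyl gives a 4.8-fold lower number from compound 2 to compound 3 (0.68 log units; beyond the scatter), so at this place, para to a large group, the number responds to the presence of the oxygen and not only to what sits on that oxygen. Measured against the ethoxy of the first compound, the trifluoromethyl gives a 14-fold lower number from compound 1 to compound 3 (1.15 log units; beyond the scatter), the only step among these three compounds that is rated large, and it shows that the two modest changes together span a wide range at a single position. The data offer no measurement that accounts for either step.

On these data alone, all three compounds keep the shared core and the other aromatic ring with its fluorine, so it stays open whether the same order of these three groups would hold if either of those parts were changed. As far as these compounds go, it also stays open how this position would respond to a group such as a nitrile, a methyl, an amine or a carboxylic acid, or to a longer chain such as pentafluoroethyl, in place of the trifluoromethyl.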